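Replacing a pyridyl ring with a carboxypyridyl ring

The source may hold more compounds than are shown below. What is called first, only, known or untested is meant among the compounds shown, and "the series" means these compounds.

Measured so far:
compound 1 `O=C(CCc1ccc(-c2ccccc2)cc1)c1ncc(-c2ccncc2)o1` – 2.3 nM
compound 2 `CCOC(=O)c1cccc(-c2cnc(C(=O)CCc3ccc(-c4ccccc4)cc3)o2)n1` – 3 nM
compound 3 `COC(=O)c1cccc(-c2cnc(C(=O)CCc3ccc(OC4CCN(C(=O)OC(C)(C)C)CC4)cc3)o2)n1` – 32 nM

In an assay for inhibition of Fatty-acid amide hydrolase 1 (Rattus norvegicus) (a higher number here means a weaker inhibitor, a lower number a stronger inhibitor), compound 1 gives the lowest number of the three. Compound 2 sits close to it, and the two lie within the usual scatter of each other, so no order between them can be claimed. Compound 3 stands well apart, with a number that is beyond the scatter, so compound 3 is the weaker inhibitor of the three.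

The step followed here leads from compound 1 to compound 4 `O=C(O)c1ccc(-c2cnc(C(=O)CCc3ccc(-c4ccccc4)cc3)o2)cn1`, which has not yet been measured. The change is 6-carboxypyridin-3-yl in place of pyridin-4-yl on an aromatic carbon. For the measured compounds named here, the entering group brings a carboxylic acid, a hydrogen-bond donor that none of the measured compounds carry, so there is no direct comparison to lean on. Given this, compound 4 is expected to be a somewhat weaker inhibitor than compound 1, a step of a 3.5-fold higher number from compound 1 to compound 4 (0.54 log units; beyond the scatter), just beyond the scatter, though a result within the scatter would not surprise. Compound 4 is estimated at 8 nM, with a range from 2 nM to 40 nM.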

Compound 4, inhibition constant: 44 nM
Beside the measured number, compound 4's estimate is 5.5-fold (0.74 log units) below it; measured number above the stated range.
By their numbers in this assay, from the lowest: compounds 1 and 2 (each within the scatter of the next); then compounds 3 and 4 (each within the scatter of the next).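

In this assay, putting 6-carboxypyridin-3-yl in place of pyridin-4-yl on the aromatic carbon next to the ring oxygen gives a 19-fold higher number from compound 1 to compound 4 (1.28 log units; beyond the scatter), a large loss of inhibition, so this position does not tolerate every pyridine-based group equally. The step makes two changes together: the ring's point of attachment moves, and a carboxylic acid enters, so this one comparison cannot separate their contributions. Nothing available here explains the loss.

The compounds shown leave open whether the carboxylic acid, the changed ring attachment or the two together account for the step. An unsubstituted pyridin-3-yl ring would address the attachment alone, while a primary amide in place of the carboxylic acid on the same ring would address the acid itself.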